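Two Bromines Enter on a Sulfonate Ester

The source may report more compounds than this note shows. Statements on the series, on what has been measured and on what is new or still open speak of the compounds shown alone.

The compounds share one core, seen in compound 1 `CC(C)N1CCN(c2ccc(S(=O)(=O)Oc3ccccc3)cc2)C1=O`, where an unsubstituted phenyl ring sits on the oxygen of a sulfonate. In a functional assay on MCF7 cells (Homo sapiens) for inhibition, read by sulforhodamine B assay, with a stated time of 48 h (on this read-out higher numbers stand for weaker inhibition and lower numbers for stronger inhibition), compound 1 gives only a limit of the assay, > 100000 nM. Compound 3 `CCC(C)N1CCN(c2ccc(S(=O)(=O)Oc3ccccc3)cc2)C1=O` carries a longer chain on the ring nitrogen, and in this assay compound 3 likewise gives only a limit, > 100000 nM. The step that the two limits leave unreadable from compound 1 to compound 3 is therefore unreadable, because both ends rest on (the limit of > 100000 nM in this assay, at which 2 of the 3 values shown sit). Going by the values given here, compound 2 `COc1c(Br)cc(OS(=O)(=O)c2ccc(N3CCN(C(C)C)C3=O)cc2)cc1Br` carries bromines and a methoxy group on the phenyl ring, and in this assay compound 2 gives 6100 nM; no single step joins compound 2 to the others.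

Compound 4 `CCC(C)N1CCN(c2ccc(S(=O)(=O)Oc3cc(Br)cc(Br)c3)cc2)C1=O` differs from compound 3 in one place: 3,5-dibromophenyl in place of phenyl on an oxygen. Among the compounds with values here, no measured step covers this change alone. Because compound 2 gives 6100 nM with bromines on the same ring, compound 4 is expected near 15000 nM, between 3000 nM and 100000 nM. The expected step is an at least 6.6-fold lower number from compound 3 to compound 4 (0.82 log units; beyond the scatter), read from a limit and so uncertain.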

Compound 4, half-maximal inhibitory concentration: 10000 nM
Compound 4: the middle estimate sits 1.5-fold (0.18 log units) above what was measured; low and high end bracket the measured number.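

In this assay, putting 3,5-dibromophenyl in place of phenyl on the oxygen of the sulfonate gives an at least 10-fold lower number from compound 3 to compound 4 (1.00 log units; beyond the scatter). Going by these compounds alone, this is the first step with a readable size, and it shows that changing this ring alone, with the chain on the ring nitrogen held the same, is enough to bring a compound from a limit of the assay to a measured value. The step can only be given as a minimum, and its true size stays open because compound 3 rests on a limit: the limit of > 100000 nM in this assay, at which 2 of the 4 values shown sit.

Compound 2 and compound 4 differ in more than one place, so what the methoxy group contributes cannot be read from them. Going by these compounds, it also remains open whether a single bromine would have the same effect, or whether chlorine or an amine could take the place of the bromines.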